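The source may report more compounds than this note shows. Statements on the series, on what has been measured and on what is new or still open speak of the compounds shown alone.

Three compounds with a shared core have numbers in an ADME assay on A549 cells (Homo sapiens) for cytotoxicity, read by resazurin assay, with a stated time of 48 h; a higher number here means that more compound is tolerated, a lower number that less compound is tolerated. Compound 1 `O=C(Nc1ccc(NC2CCCCC2)cc1Cl)c1cc(Cl)ccc1O` gives 68300 nM, compound 2 `O=C(Nc1ccc(N(CC2CC2)CC2CC2)cc1Cl)c1cc(Cl)ccc1O` gives 12800 nM, and compound 3 `CC(C)(CCO)Nc1ccc(NC(=O)c2cc(Cl)ccc2O)c(Cl)c1` gives 170000 nM, the highest of the three.

Compound 4 `O=C(Nc1ccc(NCCCO)cc1Cl)c1cc(Cl)ccc1O` has not yet been measured. It differs from compound 3 in one place: 3-hydroxypropyl in place of 3-hydroxy-1,1-dimethylpropyl on a nitrogen on an aromatic ring. Put simply, 3-hydroxypropyl stands in place of 3-hydroxy-1,1-dimethylpropyl on a nitrogen on an aromatic ring.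

Among the compounds with values here, no measured step makes this exact change. The closest evidence is a 2.5-fold higher number from compound 1 to compound 3 (0.40 log units; beyond the scatter), a modest step, and a 13-fold higher number from compound 2 to compound 3 (1.12 log units; beyond the scatter), a large one. Each of those two steps replaces a group containing rings with an open chain, whereas here one open chain replaces another. A smaller change therefore seems likely, and no step beyond the scatter is expected in this assay. The estimate amounts to a 1.1-fold higher number from compound 3 to compound 4 (0.02 log units; within the scatter). For compound 4 the expected value is 180000 nM, with an estimated range from 70000 nM to 400000 nM.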

Compound 4, half-maximal cytotoxic concentration: 106000 nM
Compound 4: the middle estimate sits 1.7-fold (0.23 log units) above what was measured, within the range that was stated.
By their numbers in this assay, from the lowest: compound 2; then compounds 1, 4 and 3 (each within the scatter of the next, the first and the last beyond it).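

Shortening 3-hydroxy-1,1-dimethylpropyl to 3-hydroxypropyl on the nitrogen gives a 1.6-fold lower number from compound 3 to compound 4 (0.21 log units; within the scatter) in this assay and so the 1,1-dimethyl branch is not needed to keep this number high. Set against cyclohexyl the unbranched chain gives a 1.6-fold higher number from compound 1 to compound 4 (0.19 log units; within the scatter) and set against bis(cyclopropylmethyl)amino it gives an 8.3-fold higher number from compound 2 to compound 4 (0.92 log units; beyond the scatter) and only this second step lies beyond the scatter. No independent measurement here explains why these changes have the sizes they do.

The compounds shown leave open whether the hydroxyl at the end of the chain matters, which a plain propyl chain would test against compound 4. They also leave open how a shorter chain such as 2-hydroxyethyl, or a chain ending in an amine or a carboxylic acid, would fare in this assay on this nitrogen.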